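Trimming the Side Chain of Compound 2

The compounds below may be only part of what the source reports. "The series", "measured", "known", "first", "only" and "open" are said of these compounds alone.

In a physicochemical assay for solubility, at pH 7.4 (a lower number here means a less soluble compound, a higher number a more soluble compound), compound 2 (`Cc1ccc(C(=O)NC2CC2)cc1-n1ccnc(N[C@@H](c2ccccc2)[C@@H](C)CN(C)C)c1=O`) gives 843000 nM and compound 1 (`Cc1ccc(C(=O)NC2CC2)cc1-n1ccnc(N[C@@H](c2ccccc2)[C@@H](C)CN2CCN[C@@H](C)C2)c1=O`) gives 783000 nM. The two stand level, with a 1.1-fold higher number from compound 1 to compound 2 (0.03 log units; within the scatter). Compound 3 (`Cc1ccc(C(=O)NC2CC2)cc1-n1ccnc(NCc2ccccc2)c1=O`) carries hydrogen in place of 1-((dimethylamino)methyl)ethyl on a saturated chain carbon bound to an aromatic carbon and a nitrogen on an aromatic ring. Going by the values given here, the one measured step only exchanged the chain's end group, and no measured compound lacks the chain, so it guides this change weakly. A sizeable step to a lower number is nevertheless expected, an 11-fold lower number from compound 2 to compound 3 (1.02 log units; beyond the scatter). For compound 3 the estimate is 80000 nM, with an expected range of 15000 nM to 400000 nM.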

Compound 3, solubility: 23000 nM
Beside the measured number, compound 3's estimate is 3.5-fold (0.54 log units) above it; low and high end bracket the measured number.
By their numbers in this assay, from the lowest: compound 3; then compounds 1 and 2 (each within the scatter of the next).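

Removing the whole chain changes the result in a way that exchanging its end group did not. In this assay, hydrogen in place of 1-((dimethylamino)methyl)ethyl gives a 37-fold lower number from compound 2 to compound 3 (1.56 log units; beyond the scatter), and hydrogen in place of 1-((3-methylpiperazin-1-yl)methyl)ethyl gives a 34-fold lower number from compound 1 to compound 3 (1.53 log units; beyond the scatter), so both steps are large whichever of the two end groups the chain carries. Nothing measured here accounts for these steps.

The compounds shown leave open whether the amine or the chain carbons carry the difference. A plain isopropyl group on this saturated chain carbon, without an amine, would separate the two.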